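This account rests on a few compounds, and the source may have more. Where it says the series, first, only, none or still open, it means among the compounds named here.

Compound 1 `COc1cc2c(cc1OC)C(CC(N)=O)CC2` gives 26.7%; compound 2 `CNC(=O)CC1CCc2cc(OC)c(OC)cc21` gives 33.3%; compound 3 `CCNC(=O)CC1CCc2cc(OC)c(OC)cc21` gives 33.3%.

All three numbers come from a functional assay on the whole organism (strain Wistar) for inhibition, with Rattus norvegicus as the target, read by paw edema, with stated times of 60 min and 24 h, at a dose of 100 mg/kg by the oral route; on this read-out lower numbers stand for less inhibition and higher numbers for more inhibition at the one dose given (going by the name of the read-out). Compound 3 stands level with compound 2, as no change at the digits printed from compound 2 to compound 3 (within the scatter) shows, and the step of a number 6.6 percentage points higher from compound 1 to compound 3 (within the scatter) is within the scatter, so the three numbers cannot be told apart. Compound 4 `CCN(CC)C(=O)CC1CCc2cc(OC)c(OC)cc21` differs from compound 3 by ethyl in place of hydrogen on an amide-type nitrogen. Going by the values given here, two measured steps bear on this, since each puts methyl or ethyl in place of hydrogen on an amide-type nitrogen: a number 6.6 percentage points higher from compound 1 to compound 2 (within the scatter) and a number 6.6 percentage points higher from compound 1 to compound 3 (within the scatter), both within the scatter. The same kind of change is therefore expected to move the number no further than the scatter, so the expected step is a number 0.3 percentage points lower from compound 3 to compound 4 (within the scatter). Compound 4 is estimated at 33%, between 18% and 48%.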

Compound 4, a percentage reported as inhibition, in the whole organism at one dose (the size of the read-out at that dose, not a potency): 16.7%
Compound 4: middle estimate off by 16.3 percentage points, on the high side, outside the stated range (below it).
By their numbers in this assay, from the lowest: compounds 4, 1, 2 and 3 (each within the scatter of the next, the first and the last beyond it).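

In this assay, going by these compounds alone, replacing the last hydrogen on the amide-type nitrogen with ethyl is the first change here to give a step beyond the scatter (a number 16.6 percentage points lower from compound 3 to compound 4 (beyond the scatter)), and diethylamino in place of methylamino on the carbonyl carbon gives the same result (a number 16.6 percentage points lower from compound 2 to compound 4 (beyond the scatter)). Diethylamino in place of amino stays within the scatter (a number 10 percentage points lower from compound 1 to compound 4 (within the scatter)), so the loss shows only against the compounds with one group on that nitrogen. No measurement shown explains this.

The compounds shown leave open whether any two groups on that nitrogen give this result, as dimethylamino or pyrrolidine on the carbonyl carbon could show.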